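The source may report more compounds than this note shows. Statements on the series, on what has been measured and on what is new or still open speak of the compounds shown alone.

Values measured in a functional assay on MIA PaCa-2 cells (Homo sapiens) for inhibition, read by MTT assay; a higher number here means a weaker inhibitor, a lower number a stronger inhibitor:

- Compound 1 `O=C(Nc1ccccc1)c1cc2cnc(N3CCN(c4ccc(Cl)cc4)CC3)nc2n1C1CCCC1`: > 200000 nM
- Compound 2 `CN(C)C(=O)c1cc2cnc(Nc3ccc(N4CCNCC4)cn3)nc2n1Cc1ccccc1`: 30400 nM
- Compound 3 `COc1ccc(NC(=O)c2cc3cnc(Nc4ccc(N5CCNCC5)cn4)nc3n2C2CCCC2)cc1`: 2880 nM

Compound 1 gives > 200000 nM, which is a limit of the assay and not a number. Among the two true numbers, compound 3 at 2880 nM has the lower one. Compound 2 gives 30400 nM, and the gap between these two values lies beyond the scatter.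

The next compound to be tested is compound 4 `O=C(Nc1ccccc1C(F)(F)F)c1cc2cnc(Nc3ccc(N4CCNCC4)cn3)nc2n1C1CCCC1`. It differs from compound 3 in one place: 2-(trifluoromethyl)phenyl in place of 4-methoxyphenyl on an amide-type nitrogen. Here 2-(trifluoromethyl)phenyl stands in place of 4-methoxyphenyl on an amide-type nitrogen.

For the measured compounds named here, no measured pair of compounds differs in just one place, so the data give no direct guide to this swap. Going by the values given here, compound 3 holds the lowest number so far at 2880 nM, so a moderate move toward weaker inhibition in this assay seems more likely than a gain. The expected change is a 1.7-fold higher number from compound 3 to compound 4 (0.24 log units; within the scatter), a modest step that may not clear the scatter. For compound 4 the estimated value is 5000 nM, with an expected range of 1500 nM to 20000 nM.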

Compound 4, half-maximal inhibitory concentration: 3160 nM
Estimate against measurement, compound 4: 1.6-fold (0.20 log units) above; low and high end bracket the measured number.
By their numbers in this assay, from the lowest: compounds 3 and 4 (each within the scatter of the next); then compound 2. At a limit, above all of these: compound 1.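

In this assay, for the compounds shown here, this is the first step between two compounds that differ in one place, and it concerns the ring group on the amide-type nitrogen: putting 2-(trifluoromethyl)phenyl in place of 4-methoxyphenyl gives a 1.1-fold higher number from compound 3 to compound 4 (0.04 log units; within the scatter). For this one pair, then, exchanging an oxygen-bearing group for a fluorine-bearing one at this place leaves the reading within the scatter. Nothing measured here bears on why the reading stays within the scatter.

From the compounds shown here alone, it remains open whether this insensitivity holds for groups of a different kind on the same nitrogen, such as a 4-carboxyphenyl group or a cyclohexyl ring. A single pair also cannot show whether either substituent matters on its own, since the phenyl ring without any substituent on this same scaffold would be needed for that comparison.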